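A few compounds are considered here, and "the series" means these few. Any claim that something is new, unique, unknown or untested is made for them only; others in the source may bear on it.

Measured compounds: compound 1 `C[C@@H](NC(=O)c1ccc(C#Cc2ccccc2F)cn1)C(C)(C)O` with 29.6%; compound 2 `Cc1ccccc1C#Cc1ccc(C(=O)N[C@H](C)C(C)(C)O)nc1` with 24.1%; compound 3 `Cc1cccc(C#Cc2ccc(C(=O)N[C@H](C)C(C)(C)O)nc2)c1` with 20.8%.

In an ADME assay on HEK293 cells for agonist activity at metabotropic glutamate receptor 5 (Rattus norvegicus), read by fluorescence and calcium flux (on this read-out higher numbers stand for larger maximal responses and lower numbers for smaller maximal responses), compound 1 stands highest of the three numbers, but its steps to the others, a number 5.5 percentage points lower from compound 1 to compound 2 (within the scatter) and a number 8.8 percentage points lower from compound 1 to compound 3 (within the scatter), both lie within the scatter, as does a number 3.3 percentage points lower from compound 2 to compound 3 (within the scatter). Compound 4 `C[C@@H](NC(=O)c1ccc(C#Cc2cccc(F)n2)cn1)C(C)(C)O` differs from compound 1 in one place: 6-fluoropyridin-2-yl in place of 2-fluorophenyl on a triple-bonded carbon. Going by the values given here, none of the measured steps exchanges the ring itself; they only vary fluoro and methyl, and all stayed within the scatter. On that basis no step beyond the scatter is expected, a number 2.6 percentage points lower from compound 1 to compound 4 (within the scatter). Compound 4 is therefore estimated at 27%, within a range from 12% to 42%.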

Compound 4, largest response reached (reported as efficacy), in percent of the reference or control that the assay uses: 8.3%
Compound 4: the middle estimate sits 18.7 percentage points above what was measured; the measured number lies below the stated range.
By their numbers in this assay, from the lowest: compound 4; then compounds 3, 2 and 1 (each within the scatter of the next).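

In this assay, changing the ring itself on the triple-bonded carbon moves the number beyond the scatter, which varying fluoro and methyl did not do: the steps are (a number 21.3 percentage points lower from compound 1 to compound 4 (beyond the scatter)), (a number 15.8 percentage points lower from compound 2 to compound 4 (beyond the scatter)) and (a number 12.5 percentage points lower from compound 3 to compound 4 (beyond the scatter)). All three comparisons, whichever aryl group leaves, put the 6-fluoropyridin-2-yl compound lowest, so this position responds to the ring as well as to its substituent. Nothing shown here gives a reason for this. Going by these compounds, it remains open whether the ring nitrogen alone carries the step or only acts together with the fluoro group. An unsubstituted pyridin-2-yl or a 6-methylpyridin-2-yl group at this place would separate the two.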